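The source may hold more compounds than are shown below. What is called first, only, known or untested is meant among the compounds shown, and "the series" means these compounds.

Measured so far in a functional assay on K562 cells (Homo sapiens) for cytotoxicity, read by MTT assay, with a stated time of 72 h; on this read-out lower numbers stand for higher toxicity in this test and higher numbers for lower toxicity in this test:
- compound 1 `C[Se]/C(=N\C(=O)c1cc2ccccc2s1)NC(=O)c1cc2ccccc2s1` gives 89600 nM.
- compound 2 `CS/C(=N\C(=O)c1ccco1)NC(=O)c1ccco1` reaches only the limit of the test, > 100000 nM, and no number.
- compound 3 `C[Se]/C(=N\C(=O)c1cnc2ccccc2c1)NC(=O)c1cnc2ccccc2c1` gives 74800 nM.

Compound 3 stands within the usual scatter of compound 1, so the two cannot be told apart on these numbers. One of the three values is a limit (the limit of > 100000 nM in this assay, at which 1 of the 3 values shown sits). Among the measured compounds shown here, no pair of measured compounds differs in a single place, so no measured step exists to lean on.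

Compound 4 `CS/C(=N\C(=O)c1cnc2ccccc2c1)NC(=O)c1cnc2ccccc2c1` is not yet measured. It differs from compound 3 by a group of 2 heavy atoms (1 carbon, 1 sulfur; no ring) in place of a group of 2 heavy atoms (1 carbon, 1 selenium; no ring), on a carbon with a double bond to nitrogen. Compound 2 carries the same methylsulfanyl group on another core, and in this assay compound 2 gives only a limit.

The step from compound 3 to compound 4 is expected to be a loss of toxicity, of the size a 2.1-fold higher number from compound 3 to compound 4 (0.33 log units; beyond the scatter). Compound 4 is therefore estimated at 160000 nM in this assay, with a range from 60000 nM to 400000 nM, and a fair chance that only a limit is reported.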

Compound 4, concentration lethal to 50% of the cells: > 100000 nM
Compound 4 was reported as a limit; the forecaster's own chance of this, stated with the estimate: 60%; the middle value lies beyond the limit too.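

Among the compounds shown here, compound 3 and compound 4 form the first pair in this assay that differs in one place, on a carbon with a double bond to nitrogen, and the result for compound 4 is a limit of the test, not a number. The step is an at least 1.3-fold higher number from compound 3 to compound 4 (0.12 log units; that floor lies within the scatter), so only its floor is known, and that floor does not separate the selenium compound from the methylsulfanyl compound. Compound 2 and compound 4, which both carry methylsulfanyl on different cores, sit at the same limit: the limit of > 100000 nM in this assay, at which 2 of the 4 values shown sit.

Going by these compounds, the true size of the step from selenium to sulfur stays open, as does whether the same exchange on the core of compound 1 would give a similar step. The compounds shown also say nothing about a longer chain, such as ethyl, or an amine at that carbon.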